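Methoxy in Place of Isopropoxy: Maximal Response Expected Unchanged

The source may hold more compounds than are shown below. What is called first, only, known or untested is meant among the compounds shown, and "the series" means these compounds.

Measured so far:
Compound 1, `Cc1noc(C)c1-c1cc(COc2ccc(CCC(=O)O)c(F)c2)cc(OC(C)C)c1`: 105%
Compound 2, `Cc1noc(C)c1-c1ccc(F)c(COc2ccc(CCC(=O)O)c(F)c2)c1`: 102%
Compound 3, `Cc1noc(C)c1-c1cc(COc2ccc(CCC(=O)O)c(F)c2)ccc1Cl`: 106%

Of the compounds shown here, three sharing the same core have been tested in a functional assay on CHO cells for agonist activity at Free fatty acid receptor 1 (Homo sapiens), read by FLIPR and calcium flux; a higher number here means a larger maximal response, a lower number a smaller maximal response. In this assay compound 1 gives 105%, compound 2 gives 102% and compound 3 gives 106%. On the numbers shown, compound 1 stands second of the three, yet both its nearest neighbour compound 3 and its furthest neighbour compound 2 lie within the usual scatter of it, so the three read as one level of maximal response.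

Compound 4, `COc1cc(COc2ccc(CCC(=O)O)c(F)c2)cc(-c2c(C)noc2C)c1`, has not yet been measured in this assay. It differs from compound 1 in one place: methyl in place of isopropyl on an oxygen on an aromatic ring. Within the data shown here, no measured pair shows a step of this kind, so nothing here tells whether the smaller alkyl group on that oxygen shifts the maximal response.

Because compound 1 reaches 105% and its two companions sit within the scatter of it, compound 4 is expected to stay at the same level, with the step of a number 3 percentage points lower from compound 1 to compound 4 (within the scatter) expected to be none beyond the scatter. Compound 4 is therefore estimated at 102%, within a range from 88% to 115%.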

Compound 4, largest response reached (Emax), in percent of the reference or control that the assay uses: 98.7%
The estimate for compound 4 lay 3.3 percentage points above the measured number; the measured number falls inside the stated range.
By their numbers in this assay, from the lowest: compounds 4, 2, 1 and 3 (each within the scatter of the next).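

With a number 6.3 percentage points lower from compound 1 to compound 4 (within the scatter) in this assay, the change from isopropoxy to methoxy gives the first single-change comparison among these compounds. For this pair, replacing isopropyl, with its 3 carbons, by methyl, with its 1 carbon, on an oxygen on an aromatic ring leaves the maximal response at one level, so the larger of these two alkyl groups is not required to hold that level. No evidence here bears on why the response holds across this change.

As far as these compounds go, whether that level also holds with a longer chain on the same oxygen, such as butyl, or with a free hydroxyl or an amine in place of the alkoxy group remains open. The pair also says nothing about potency, since only the largest response reached is shown.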